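The compounds below may be only part of what the source reports. "The series", "measured", "known", "first", "only" and "open" are said of these compounds alone.

Measured so far in a functional assay on HCT-116 cells (Homo sapiens) for antiproliferative activity, with a stated time of 72 h; on this read-out lower numbers stand for stronger inhibition and higher numbers for weaker inhibition

Compound 1 `CCCCC#Cc1cc([C@@H]2O[C@H](CO)[C@@H](O)[C@H]2O)n2ncnc(N)c12` gives 2900 nM
Compound 2 `COc1ccc(-c2cc([C@@H]3O[C@H](CO)[C@@H](O)[C@H]3O)n3ncnc(N)c23)cc1` gives 47100 nM

Compound 2 has the higher number of the two, so it is the weaker inhibitor. Compound 3 `Nc1ncnn2c([C@@H]3O[C@H](CO)[C@@H](O)[C@H]3O)cc(/C=C/c3ccccc3)c12` carries 2-phenylethenyl in place of 4-methoxyphenyl on an aromatic carbon, which adds a double bond outside aromatic rings. Going by the values given here, the only measured step at this carbon is large (a 16-fold higher number from compound 1 to compound 2 (1.21 log units; beyond the scatter)), showing that the group there can shift the number strongly in this assay. A moderately lower number is expected, with an estimated step of a 3.1-fold lower number from compound 2 to compound 3 (0.50 log units; beyond the scatter) here. With a single step as a guide, the range stays wide. The estimate for compound 3 is 15000 nM (range 4000 nM to 50000 nM).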

Compound 3, half-maximal inhibitory concentration: 4800 nM
Beside the measured number, compound 3's estimate is 3.1-fold (0.49 log units) above it, and the stated range covers the measured number.
By their numbers in this assay, from the lowest: compounds 1 and 3 (each within the scatter of the next); then compound 2.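

In this assay, 2-phenylethenyl in place of 4-methoxyphenyl on this aromatic carbon gives a 9.8-fold lower number from compound 2 to compound 3 (0.99 log units; beyond the scatter) and so shows that a six-membered aromatic ring at this carbon does not by itself bring the weak result of compound 2. Set against hex-1-yn-1-yl, the same group gives a 1.7-fold higher number from compound 1 to compound 3 (0.22 log units; within the scatter) and so leaves two quite different groups that cannot be told apart here. Going by these compounds, whether an amine, a carboxylic acid or a shorter chain at this carbon would give a similarly low number stays open. No available evidence explains these differences.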